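A few compounds are considered here, and "the series" means these few. Any claim that something is new, unique, unknown or untested is made for them only; others in the source may bear on it.

Measured so far:
Compound 1 `ClCc1ccccc1Cn1cnc2c(Cl)nc(Cl)nc21`: in a functional assay on T47D cells (Homo sapiens) for cytotoxicity, read by sulforhodamine B assay, with a stated time of 48 h (on this read-out higher numbers stand for lower toxicity in this test and lower numbers for higher toxicity in this test), compound 1 gives > 100000 nM, which is a limit of the assay rather than a number.
Compound 2 `ClCc1ccc(Cn2cnc3nc(Cl)nc(Cl)c32)cc1`: in this assay compound 2 gives > 100000 nM, again a limit of the assay.
Compound 3 `ClCc1cccc(Cn2cnc3c(Cl)nc(Cl)nc32)c1`: in this assay compound 3 gives > 100000 nM, also a limit of the assay.

Compound 2 therefore stands exactly where the other two measured compounds stand: at the limit of this test, without a number that would place it higher or lower than them. The three share the same core and differ only in where the chloromethyl group sits on the benzyl ring, and the whole body of evidence on them is this: the limit of > 100000 nM in this assay, at which 3 of the 3 values shown sit.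

Compound 4 `ClCc1ccc(Cn2cnc3ncnc(Cl)c32)cc1` has not been measured yet. It differs from compound 2 in a single place: hydrogen in place of chloro on an aromatic carbon. Within the data shown here, no step between measured compounds is available, so the size of the change this brings in this assay cannot be read off from anything measured. The expectation rests on compound 2 alone, and because compound 2 gives > 100000 nM a move beyond the scatter is not expected. The expected step of a number no higher from compound 2 to compound 4 (the limit leaves the size open) is estimated to be none beyond the scatter. Compound 4 is expected to give 100000 nM in this test, within 30000 nM to 300000 nM, most likely reported again only as a limit.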

Compound 4, concentration lethal to 50% of the cells: 6300 nM
Estimate against measurement, compound 4: 16-fold (1.20 log units) above; the measured number lies below the stated range.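

In this assay compound 2 gives only a limit, > 100000 nM, and the earlier compounds offered nothing more than that same ceiling, with no number to compare: the limit of > 100000 nM in this assay, at which 3 of the 4 values shown sit.
Putting hydrogen in place of the chloro on the aromatic carbon between two ring nitrogen atoms brings an at least 15-fold lower number from compound 2 to compound 4 (1.20 log units; beyond the scatter), and on this read-out a lower number stands for higher toxicity in this test. This is the first single change shown that moves a compound off the limit, which marks this carbon as a place where the choice of atom matters, while the other chloro and the chloromethyl group stay the same in both compounds.

What the compounds shown leave open is whether hydrogen is special at this carbon or whether an amine, a methoxy group or a methyl group there would also bring the number down, and by how much. On these data alone, it also remains open whether the place of the chloromethyl group on the benzyl ring, which could not be told apart at the limit, makes a difference once this chloro is gone.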